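This account rests on a few compounds, and the source may have more. Where it says the series, first, only, none or still open, it means among the compounds named here.

Among the three compounds measured so far in an ADME assay on Vero cells (Chlorocebus sabaeus) for cytotoxicity (on this read-out higher numbers stand for an effect only at larger amounts of compound and lower numbers for an effect already at smaller amounts), compound 3 `N=c1c2ncnc(Nc3ccccc3)c2ncn1NC(=O)c1ccncc1` stands at the top with 4.37 ug/mL. Compound 2 `COc1ccc(Nc2ncnc3c(=N)n(NC(=O)c4ccccc4)cnc23)cc1` gives 2.12 ug/mL, and compound 1 `COc1ccc(Nc2ncnc3c(=N)n(NC(=O)c4ccncc4)cnc23)cc1` gives 1.15 ug/mL. Among the measured compounds shown here, compound 3 is thus a modest distance from compound 2 and further from compound 1; the step of a 3.8-fold higher number from compound 1 to compound 3 (0.58 log units; beyond the scatter) concerns a hydrogen in place of methoxy on an aromatic carbon and is the single measured step beyond the scatter.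

Compound 4 `N=c1c2ncnc(Nc3ccccc3)c2ncn1NC(=O)c1ccccc1` differs from compound 3 in one place: phenyl in place of pyridin-4-yl on a carbonyl carbon. The same change has been seen once already, in the step of a 1.8-fold higher number from compound 1 to compound 2 (0.27 log units; within the scatter), which stayed within the scatter. The step from compound 1 to compound 3 changes a different position and does not bear on this one.

On that basis compound 4 is expected to move only a little in this assay, with a step of about a 1.6-fold higher number from compound 3 to compound 4 (0.20 log units; within the scatter) in the upward direction, not clearly beyond the scatter. Compound 4 is therefore estimated at 7 ug/mL, with a likely range from 3.8 ug/mL to 13 ug/mL.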

Compound 4, half-maximal effective concentration: 2.35 ug/mL
For compound 4 the middle estimate is 3.0-fold (0.47 log units) above the measured one, outside the stated range (below it).
By their numbers in this assay, from the lowest: compounds 1, 2, 4 and 3 (each within the scatter of the next, the first and the last beyond it).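

In this assay, the exchange of pyridin-4-yl for phenyl on a carbonyl carbon now gives a 1.9-fold lower number from compound 3 to compound 4 (0.27 log units; within the scatter), which points the other way from the step seen with methoxy on the core, although each step alone stays within the scatter: the same change on two cores in this assay, a 1.8-fold higher number (0.27 log units; within the scatter) from compound 1 to compound 2 and a 1.9-fold lower number (0.27 log units; within the scatter) from compound 3 to compound 4, 3.4-fold (0.54 log units) apart, beyond the scatter of two such steps. The change from methoxy to hydrogen on an aromatic carbon also depends on its partner, since with the benzamido group it gives only a 1.1-fold higher number from compound 2 to compound 4 (0.04 log units; within the scatter), whereas the same change with the ((pyridin-4-yl)carbonyl)amino group went beyond the scatter: the same change on two cores in this assay, a 3.8-fold higher number (0.58 log units; beyond the scatter) from compound 1 to compound 3 and a 1.1-fold higher number (0.04 log units; within the scatter) from compound 2 to compound 4, 3.4-fold (0.54 log units) apart, beyond the scatter of two such steps. Across these four compounds the two positions therefore do not add up independently.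

Going by these compounds, whether this coupling extends to other groups remains open, for example a pyridin-3-yl or a short alkyl chain on the carbonyl carbon. The same holds for a chlorine or an amine in place of methoxy on the aromatic carbon.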